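The compounds below may be only part of what the source reports. "The series", "measured", "known", "first", "only" and "open" are said of these compounds alone.

Measured so far in a functional assay on PC-3 cells (Homo sapiens) for antiproliferative activity, read by MTT assay, with a stated time of 72 h; a higher number here means a weaker inhibitor, a lower number a stronger inhibitor:
- compound 1 `CN(C)CCn1cccc1/C=N/NC(=O)Nc1ccc(Oc2ccnc3[nH]ccc23)cc1` gives 3930 nM
- compound 2 `CN(C)CCCn1cccc1/C=N/NC(=O)Nc1ccc(Oc2ccnc3[nH]ccc23)cc1` gives 5150 nM
- compound 3 `CN1CCN(CCCn2cccc2/C=N/NC(=O)Nc2ccc(Oc3ccnc4[nH]ccc34)cc2)CC1` gives 3740 nM

At 3740 nM compound 3 sits within the scatter of both neighbours, so the three values form one level with no order among them. The next compound is compound 4 `O=C(N/N=C/c1cccn1CCCN1CCCC1)Nc1ccc(Oc2ccnc3[nH]ccc23)cc1`, with pyrrolidin-1-yl in place of 4-methylpiperazin-1-yl on a saturated chain carbon, three bonds along the chain from an aromatic nitrogen. The counted difference is pyrrolidin-1-yl in place of 4-methylpiperazin-1-yl on a saturated chain carbon, three bonds along the chain from an aromatic nitrogen and it concerns the same place as the closest measured precedent, a 1.4-fold lower number from compound 2 to compound 3 (0.14 log units; within the scatter), which exchanges dimethylamino for 4-methylpiperazin-1-yl. The other two steps, a 1.3-fold higher number from compound 1 to compound 2 (0.12 log units; within the scatter) and a 1.1-fold lower number from compound 1 to compound 3 (0.02 log units; within the scatter), are just as small. Within the data shown here, no measured compound carries pyrrolidin-1-yl, so the expectation rests on these three compounds alone, none of which goes against the flat picture. Given the size of a 1.4-fold lower number from compound 2 to compound 3 (0.14 log units; within the scatter) and the other two steps, no shift beyond the scatter is expected in this assay. The estimated step is a 1.1-fold higher number from compound 3 to compound 4 (0.05 log units; within the scatter) and it is expected to stay small. For compound 4 the estimated value is 4200 nM with an expected range from 2200 nM to 8000 nM as the working figure.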

Compound 4, half-maximal inhibitory concentration: 4290 nM
The estimate for compound 4 lay 1.0-fold (0.01 log units) below the measured number; measured number inside the range.
By their numbers in this assay, from the lowest: compounds 3, 1, 4 and 2 (each within the scatter of the next).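

Notes on the chain end, on a saturated chain carbon, three bonds along the chain from an aromatic nitrogen: in this assay, a five-membered non-aromatic ring with 1 hetero atom replaces a six-membered non-aromatic ring with 2 hetero atoms and gives only a small step (a 1.1-fold higher number from compound 3 to compound 4 (0.06 log units; within the scatter)). The same ring set against the open dimethylamino group on the same chain also stays small (a 1.2-fold lower number from compound 2 to compound 4 (0.08 log units; within the scatter)), and the comparison with the shorter chain of compound 1, which differs in both the end group and the chain, does too (a 1.1-fold higher number from compound 1 to compound 4 (0.04 log units; within the scatter)), so the flat level now extends to four compounds and none of them goes against it. No supporting data bear on this result, so the numbers stand without explanation.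

All four compounds shown end in a tertiary amine on a short chain, so it stays open whether a primary amine, a morpholin-4-yl group or a carboxylic acid at the chain end would hold this level. On these data alone, a longer chain than 3-(pyrrolidin-1-yl)propyl, and changes to the shared core rather than to this chain, also remain open.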